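The source may report more compounds than this note shows. Statements on the series, on what has been measured and on what is new or still open speak of the compounds shown alone.

Working notes on the series. Compound 1 `COc1cccc(OC)c1OCCNCCOc1ccccc1OCc1ccccc1` gives, in a functional assay on PC-3 cells (Homo sapiens) for cytotoxicity, read by sulforhodamine B assay (on this read-out lower numbers stand for stronger inhibition of growth and higher numbers for weaker inhibition of growth), a value of 76900 nM. Compound 2 `COc1cccc(OC)c1OCCNCCOc1ccccc1OCc1ccccc1C` gives in this assay 33900 nM, and compound 3 `COc1cccc(OC)c1OCCNCCOc1ccccc1OCc1ccc(C)cc1` gives in this assay 27500 nM. Compound 3 holds the lowest of the three numbers; its gap to compound 2 stays within the scatter, while the gap to compound 1 lies beyond it. The measured steps are a 2.3-fold lower number from compound 1 to compound 2 (0.36 log units; beyond the scatter) and a 2.8-fold lower number from compound 1 to compound 3 (0.45 log units; beyond the scatter), both modest, and a 1.2-fold lower number from compound 2 to compound 3 (0.09 log units; within the scatter), which stays within the scatter.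

The next member is compound 4 `COc1cccc(OC)c1OCCNCCOc1ccccc1OCc1ccc([N+](=O)[O-])cc1`. The change from compound 3 to compound 4 is nitro in place of methyl on an aromatic carbon. Going by the values given here, only the step of a 2.8-fold lower number from compound 1 to compound 3 (0.45 log units; beyond the scatter) touches the same aromatic carbon, and it concerns methyl, not nitro; no measured step concerns nitro at all. The expectation is therefore no step beyond the scatter, or at most a modest one in this assay in either direction. Compound 4 is estimated at 28000 nM, with a range from 11000 nM to 75000 nM, which means an expected step of a 1.0-fold higher number from compound 3 to compound 4 (0.01 log units; within the scatter).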

Compound 4, concentration for total growth inhibition: 43600 nM
Estimate against measurement, compound 4: 1.6-fold (0.19 log units) below; the range from low to high includes it.
By their numbers in this assay, from the lowest: compounds 3, 2, 4 and 1 (each within the scatter of the next, the first and the last beyond it).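

Going by these compounds alone, at this position, on an aromatic carbon para to a large group, nitro is the first group set against methyl, and in this assay the exchange gives a 1.6-fold higher number from compound 3 to compound 4 (0.20 log units; within the scatter) and so is not resolved by this read-out. The exchange of 2-methylphenyl for 4-nitrophenyl gives a 1.3-fold higher number from compound 2 to compound 4 (0.11 log units; within the scatter) and nitro in place of hydrogen gives a 1.8-fold lower number from compound 1 to compound 4 (0.25 log units; within the scatter) while methyl on the same carbon gives a 2.8-fold lower number from compound 1 to compound 3 (0.45 log units; beyond the scatter) so only methyl, not nitro, separates from compound 1 here. Nothing at hand bears on why the values fall this way.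

As far as these compounds go, whether an amine or a carboxylic acid on this carbon would give a step beyond the scatter stays open. So does whether any group here would move the values far from the range of these four compounds.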